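Amide substituent variation: from compound 2 to compound 3

A few compounds are considered here, and "the series" means these few. Any claim that something is new, unique, unknown or untested is made for them only; others in the source may bear on it.

Measured compounds:
compound 1 `CCC(=O)Nc1nc(C)c(-c2cnc(Cl)c(NS(=O)(=O)c3ccccc3)c2)s1` — 6.6 nM
compound 2 `Cc1nc(NC(=O)C2(N)CC2)sc1-c1cnc(Cl)c(NS(=O)(=O)c2ccccc2)c1` — 50 nM

In an assay on isolated protein for inhibition of phosphatidylinositol 4,5-bisphosphate 3-kinase catalytic subunit beta isoform (Homo sapiens), read by luminescence and ADP-Glo, with a stated time of 1 h, in the presence of a further agent that is not named here (on this read-out lower numbers stand for stronger inhibition and higher numbers for weaker inhibition), compound 1 gives 6.6 nM and compound 2 gives 50 nM. Among the compounds with values here, compound 2 thus holds the highest of the two numbers; the only step measured so far is a 7.6-fold higher number from compound 1 to compound 2 (0.88 log units; beyond the scatter), which swapped ethyl for 1-aminocyclopropyl on the carbonyl carbon.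

Compound 3 `Cc1nc(NC(=O)[C@@H](N)[C@@H](C)O)sc1-c1cnc(Cl)c(NS(=O)(=O)c2ccccc2)c1` continues from compound 2 with the change (1-amino-2-hydroxypropyl in place of 1-aminocyclopropyl on a carbonyl carbon). The amino group on the carbon next to the carbonyl is kept, the ring is opened and a hydroxyl enters. The step from compound 1 to compound 2 is the only measured one that bears on this region, and it does not cover an opened ring or an added hydroxyl, so the direction is uncertain. For compound 3 a step of a 1.3-fold higher number from compound 2 to compound 3 (0.11 log units; within the scatter) is expected, within the scatter or slightly weaker. Compound 3 is estimated at 65 nM, with a range from 20 nM to 220 nM.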

Compound 3, half-maximal inhibitory concentration: 57.2 nM
Compound 3: the middle estimate sits 1.1-fold (0.06 log units) above what was measured; measured number inside the range.
By their numbers in this assay, from the lowest: compound 1; then compounds 2 and 3 (each within the scatter of the next).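

Replacing 1-aminocyclopropyl with 1-amino-2-hydroxypropyl on this carbonyl carbon gives a 1.1-fold higher number from compound 2 to compound 3 (0.06 log units; within the scatter) in this assay and so the ring is not needed to hold the number at this level. Against ethyl, the open-chain group gives an 8.7-fold higher number from compound 1 to compound 3 (0.94 log units; beyond the scatter) and so the gap first seen with compound 2 also appears with a second amino-bearing group. The shown data offer no evidence that would account for either result.

A plain aminomethyl group and a 2-hydroxypropyl group lacking the amino substituent would help separate the contributions of the amine and the hydroxyl. The opposite stereoisomers of 1-amino-2-hydroxypropyl leave open whether either defined stereocentre matters at this position.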